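Nitro in place of chloro: compound 4 in the series

The source may report more compounds than this note shows. Statements on the series, on what has been measured and on what is new or still open speak of the compounds shown alone.

Measured in an ADME assay on J774 cells (Mus musculus) for cytotoxicity, read by resazurin assay, with a stated time of 72 h (a lower number here means that less compound is tolerated, a higher number that more compound is tolerated), so far
- compound 1 `C/C(=N\Nc1nc(-c2ccccc2)cs1)c1ccc(Cl)c(Cl)c1` gives > 50000 nM (a limit)
- compound 2 `C/C(=N\Nc1nc(-c2ccccn2)cs1)c1ccc(Cl)c(Cl)c1` gives 10100 nM (a number)
- compound 3 `C/C(=N\Nc1nc(-c2ccc(Cl)cc2)cs1)c1ccc(Cl)c(Cl)c1` gives > 50000 nM (a limit)

Compound 3 gives > 50000 nM and this is a limit, not a number. Within the data shown here, that is the limit of > 50000 nM in this assay, at which 2 of the 3 values shown sit, and compound 2 is the only compound with a number.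

Compound 4 `C/C(=N\Nc1nc(-c2ccc([N+](=O)[O-])cc2)cs1)c1ccc(Cl)c(Cl)c1` carries nitro in place of chloro on an aromatic carbon of a six-membered aromatic ring of carbon only, para to a large group, and the count for the change is nitro in place of chloro on an aromatic carbon in full.

Of the measured steps, the one at this same place is a step that the two limits leave unreadable from compound 1 to compound 3 and it supplies no size. The other two are an at least 4.9-fold lower number from compound 1 to compound 2 (0.69 log units; beyond the scatter) and an at least 4.9-fold higher number from compound 2 to compound 3 (0.69 log units; beyond the scatter) and both exchange the ring itself, so they bear on the present change only loosely. The expected change is a modest one toward a lower number, with an at least 4.9-fold lower number from compound 1 to compound 2 (0.69 log units; beyond the scatter) as the only readable fall, and compound 4 may well stay at the limit. The estimated step is an at least 1.6-fold lower number from compound 3 to compound 4 (0.22 log units; that floor lies within the scatter) and it stays uncertain while the starting point is only a limit. For compound 4 the expected value is 30000 nM with an estimated range from 9000 nM to 50000 nM in this assay for now.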

Compound 4, half-maximal cytotoxic concentration: > 50000 nM
Compound 4: only a limit was reported (the forecaster's own chance of this, stated with the estimate: 40%); middle value at least 1.6-fold (0.22 log units) from the limit.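

No step can be read from compound 1 or compound 3 to compound 4 in this assay, because each comparison has limits at both ends: the limit of > 50000 nM in this assay, at which 3 of the 4 values shown sit. The compounds shown leave open whether hydrogen, chloro and nitro at this place differ at all in how much compound is tolerated; only compound 2 has a number.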